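From carboxy to carboxymethyl in compound 1

The compounds below may be only part of what the source reports. "The series", "measured", "known", "first", "only" and "open" are said of these compounds alone.

Going by the values given here, in a functional assay on RAW264.7 cells (Mus musculus) for inhibition, with a stated time of 1 h (a lower number here means a stronger inhibitor, a higher number a weaker inhibitor), compound 1 `CCCCCCCCCCCCCCC(=O)C(=O)N[C@@H](CCCC)CCC(=O)O` gives 25000 nM, the higher of the two numbers so far, while compound 2 `CCCCCCCCCCCCCCC(=O)C(=O)NCCCC(=O)O` gives 10000 nM. Compound 3 `CCCCCCCCCCCCCCC(=O)C(=O)N[C@@H](CCCC)CCCC(=O)O` has carboxymethyl in place of carboxy on a saturated chain carbon, three bonds along the chain from an amide-type nitrogen. Among the compounds with values here, the only measured step, hydrogen in place of butyl, gave a 2.5-fold lower number from compound 1 to compound 2 (0.40 log units; beyond the scatter). It concerns a different change, so it is only a loose guide to size. In this assay, the expected result is a 1.3-fold lower number from compound 1 to compound 3 (0.10 log units; within the scatter), with no clear change beyond the scatter. Compound 3 is estimated at 20000 nM, within a range of 8000 nM to 50000 nM.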

Compound 3, half-maximal inhibitory concentration: 2000 nM
Compound 3: the middle estimate sits 10-fold (1.00 log units) above what was measured; the whole stated range lies above it.
By their numbers in this assay, from the lowest: compound 3; then compound 2; then compound 1.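

In this assay this position proves highly sensitive: carboxymethyl in place of carboxy, on a saturated chain carbon, three bonds along the chain from an amide-type nitrogen, gives a large step (a 13-fold lower number from compound 1 to compound 3 (1.10 log units; beyond the scatter)). That step is larger than the only earlier one, hydrogen in place of butyl (a 2.5-fold lower number from compound 1 to compound 2 (0.40 log units; beyond the scatter)). Nothing available explains the gain.

From the compounds shown here alone, whether 2-carboxyethyl or 3-carboxypropyl at this place would lower the number further remains open. So does whether a methyl ester or an amine could replace the carboxylic acid at the chain end.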